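The compounds below may be only part of what the source reports. "The series", "measured", "known", "first", "only" and "open" are said of these compounds alone.

Measured so far in a functional assay on HCT-116 cells (Homo sapiens) for inhibition, read by MTT assay, with a stated time of 24 h, tested at 2.5 uM; a higher number here means more inhibition of growth at the concentration tested, a lower number less inhibition of growth:
compound 1 `CS(=O)(=O)c1ccc(-c2cnc3[nH]cc(-c4nnc(-c5ccccc5)o4)c(=O)c3c2)cc1` — 0.53%
compound 2 `O=c1c(-c2nnc(-c3ccc(Cl)cc3)o2)c[nH]c2ncc(-c3cccnc3)cc12` — 10.4%

Compound 1 gives the lower of the two numbers in this assay, and compound 2 lies within the scatter of it, so the two compounds cannot be ordered on these data. Among the compounds with values here, compound 3 `Cc1cccc(-c2nnc(-c3c[nH]c4ncc(-c5ccc(S(C)(=O)=O)cc5)cc4c3=O)o2)c1` differs from compound 1 by methyl in place of hydrogen on an aromatic carbon; no such step has been measured. Within the data shown here, with only two values, both near zero, the step from compound 1 to compound 3 is expected to be small, in no fixed direction, and not beyond the scatter: a number 3.5 percentage points higher from compound 1 to compound 3 (within the scatter). Compound 3 is accordingly estimated at 4% in this assay, with a range from -5% to 15%.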

Compound 3, percent growth inhibition at one concentration: 8.13%
Estimate against measurement, compound 3: 4.1 percentage points below; the range from low to high includes it.
By their numbers in this assay, from the lowest: compounds 1, 3 and 2 (each within the scatter of the next).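

In this assay, methyl in place of hydrogen on an aromatic carbon gives a number 7.6 percentage points higher from compound 1 to compound 3 (within the scatter) as the first step read at this position, and it shows no change that can be told from the scatter. On this single pair, the 3-methylphenyl group does not lift compound 3 out of the low range seen for the series. Nothing at hand bears on the reason for this result. Going by these compounds, whether an amine, a carboxylic acid or a longer chain such as propyl at this place would give a step beyond the scatter stays open. So does the outcome of methyl on the other carbons of this phenyl ring.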